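The source may hold more compounds than are shown below. What is called first, only, known or untested is meant among the compounds shown, and "the series" means these compounds.

For the measured compounds named here, compound 2 `Cc1ccn2cc(-c3ccc(NC(=O)Nc4cc(C(C)(C)C)on4)cc3)nc2c1` holds the lowest of the two numbers so far in a functional assay on MV4-11 cells (Homo sapiens) for cytotoxicity, read by MTT assay, with a stated time of 72 h (a higher number here means a weaker inhibitor, a lower number a stronger inhibitor), where compound 2 gives 0.79 nM. Its nearest neighbour is compound 1 `CC(C)(C)c1cc(NC(=O)Nc2ccc(-c3cn4ccccc4n3)cc2)no1`, which in this assay gives 3.09 nM. Compound 3 `C#Cc1ccn2cc(-c3ccc(NC(=O)Nc4cc(C(C)(C)C)on4)cc3)nc2c1` differs from compound 2 by ethynyl in place of methyl on an aromatic carbon. Going by the values given here, no measured step swaps methyl for ethynyl; the only step touching this position, a 3.9-fold lower number from compound 1 to compound 2 (0.59 log units; beyond the scatter), shows that a small group there is tolerated. Compound 3 is therefore expected to show no step beyond the scatter, a 1.0-fold higher number from compound 2 to compound 3 (0.01 log units; within the scatter). The value of compound 3 in this assay is estimated at 0.8 nM, with a range from 0.3 nM to 2.5 nM.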

Compound 3, half-maximal inhibitory concentration in the MV4-11 assay: 3.46 nM
Estimate against measurement, compound 3: 4.3-fold (0.64 log units) below; the measured number lies above the stated range.
By their numbers in the MV4-11 assay, from the lowest: compound 2; then compounds 1 and 3 (each within the scatter of the next).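

At the carbon opposite the ring nitrogen, the outcome in the MV4-11 assay depends on the group: compound 1 gives 3.09 nM, compound 2 gives 0.79 nM and compound 3 gives 3.46 nM, so ethynyl does not keep what methyl gained, with a 4.4-fold higher number from compound 2 to compound 3 (0.64 log units; beyond the scatter) and with a 1.1-fold higher number from compound 1 to compound 3 (0.05 log units; within the scatter). In a physicochemical assay for solubility (a higher number here means a more soluble compound, a lower number a less soluble compound), compound 2 gives 3340 ug/mL and compound 3 gives 4110 ug/mL; the same swap gives a 1.2-fold higher number from compound 2 to compound 3 (0.09 log units; within the scatter) so the change separates these compounds in only one assay. Nothing measured here explains why methyl and ethynyl part. On these data alone, whether an ethyl, a nitrile or an amine at this carbon would track methyl or ethynyl stays open.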